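Methoxy in Place of Hydrogen on a Thiol Core

The source may hold more compounds than are shown below. What is called first, only, known or untested is meant among the compounds shown, and "the series" means these compounds.

Measured compounds:
compound 1 `C=CCn1ncc2c(C)nc(CC)n2c1=O`: > 48000 nM
compound 2 `Cc1nc(C)n2c(S)nncc12`: > 48000 nM
compound 3 `CCOC(=O)CSc1nncc2c(C)nc(C)n12`: > 48000 nM

In a functional assay for inhibition, with Homo sapiens as the target (a higher number here means a weaker inhibitor, a lower number a stronger inhibitor), compound 1 gives only a limit, > 48000 nM. Compound 2 likewise gives only a limit, > 48000 nM. Compound 3 also stops at a limit, > 48000 nM. Within the data shown here, compound 2 therefore stands nowhere in particular: all three values sit at the limit of > 48000 nM in this assay, at which 3 of the 3 values shown sit, and the one measured step, a step that the two limits leave unreadable from compound 2 to compound 3, cannot be read.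

Compound 4 `COCc1nc(C)c2cnnc(S)n12` differs from compound 2 by methoxy in place of hydrogen on a saturated chain carbon bound to an aromatic carbon. Among the measured compounds shown here, no measured step bears readably on this change. The step from compound 2 to compound 4 is therefore expected to be a step that the limit leaves unreadable from compound 2 to compound 4, with no movement visible. Compound 4 is estimated at 60000 nM, within 20000 nM to 200000 nM, most likely again a limit.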

Compound 4, half-maximal inhibitory concentration: > 48000 nM
Compound 4 ended at the assay's limit; the forecaster's own chance of this, stated with the estimate: 85%; the middle value lies beyond the limit too.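

Compound 2 and compound 4 both end at a limit of the assay, so no size can be read for the step between them. The compounds shown leave open which change to the shared core, if any, would give a measurable value in this assay.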